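Swapping one ring group at the limit of the assay

The compounds below may be only part of what the source reports. "The series", "measured", "known", "first", "only" and "open" are said of these compounds alone.

- Compound 1 `Cc1ccccc1NNC(=O)c1cccc(NS(=O)(=O)c2cnc(O)nc2O)c1`: > 20000 nM
- Compound 2 `Cc1ccc(C(=O)NNC(=O)c2cccc(NS(=O)(=O)c3cnc(O)nc3O)c2)cc1`: > 20000 nM

Both entries come from a functional assay on OVCAR-3 cells (Homo sapiens) for antiproliferative activity, read by MTT assay, with a stated time of 24 h (a higher number here means a weaker inhibitor, a lower number a stronger inhibitor), and each is a limit of the assay, not a number. Compound 2 therefore has no exact position, and its entry of > 20000 nM is a limit. The two compounds share one place on the scale: the limit of > 20000 nM in this assay, at which 2 of the 2 values shown sit. Going by the values given here, the only measured step is a step that the two limits leave unreadable from compound 1 to compound 2, so it offers no size to carry forward.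

The next compound, compound 3 `O=C(NNC(=O)c1ccccc1Cl)c1cccc(NS(=O)(=O)c2cnc(O)nc2O)c1`, differs from compound 2 in a single group: 2-chlorophenyl in place of 4-methylphenyl on a carbonyl carbon. Put simply, 2-chlorophenyl stands in place of 4-methylphenyl on a carbonyl carbon. Among the compounds with values here, no measured step shows what this exchange does in this assay, so no change beyond the usual scatter, in either direction, is expected. Compound 3 will most likely be reported as a limit again. The expected step is a step that the limit leaves unreadable from compound 2 to compound 3. For compound 3 the estimated half-maximal inhibitory concentration is 30000 nM, with an expected range of 10000 nM to 80000 nM.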

Compound 3, half-maximal inhibitory concentration: 7300 nM
Beside the measured number, compound 3's estimate is 4.1-fold (0.61 log units) above it, and the stated range ends above it.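

In this assay, the group on this carbonyl carbon makes a readable difference: 2-chlorophenyl in place of 4-methylphenyl gives an at least 2.7-fold lower number from compound 2 to compound 3 (0.43 log units; beyond the scatter), whereas the step between the two earlier compounds cannot be read. The broader exchange of (2-chlorophenyl)carbonyl in place of 2-methylphenyl on the amine nitrogen gives an at least 2.7-fold lower number from compound 1 to compound 3 (0.43 log units; beyond the scatter), and both sizes are minimums, with the true distance from each earlier compound still unknown. Compound 3 is the only compound shown with an exact number, while the other two stay at a shared limit: the limit of > 20000 nM in this assay, at which 2 of the 3 values shown sit.

The exchange from 4-methylphenyl to 2-chlorophenyl swaps methyl for chlorine and changes the number in the group's name at the same time, and the compounds shown cannot separate these two changes. As far as these compounds go, it also remains open whether a methoxy group or an amine on the same phenyl ring would give a lower or a higher number than the chlorine of compound 3.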